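Swapping an octyl chain for a fluorophenoxy group

The source may report more compounds than this note shows. Statements on the series, on what has been measured and on what is new or still open speak of the compounds shown alone.

Of the compounds shown here, two have been measured in an assay on microsomes from brain for inhibition of Fatty-acid amide hydrolase 1 (Rattus norvegicus), read by fluorescence and HPLC, with a stated time of 60 min; a higher number here means a weaker inhibitor, a lower number a stronger inhibitor. Compound 1 `CC(Oc1ccc(Oc2ccc(F)cc2)cc1)C(=O)Cn1nnc(-c2ccc(Cl)cc2)n1` gives 42 nM in this assay, and compound 2 `CCCCCCCCc1ccc(OC(C)C(=O)Cn2nnc(-c3ccc(C(=O)OC)cc3)n2)cc1` gives 25 nM. The two numbers lie within the usual scatter of each other, so neither compound can be called the stronger. Compound 3 `COC(=O)c1ccc(-c2nnn(CC(=O)C(C)Oc3ccc(Oc4ccc(F)cc4)cc3)n2)cc1` differs from compound 2 by 4-fluorophenoxy in place of octyl on an aromatic carbon. For the measured compounds named here, no measured pair shows this change on its own, so compound 3 is expected to sit close to compound 2, with a step from a 1.4-fold higher number from compound 2 to compound 3 (0.15 log units; within the scatter) judged within the scatter. Compound 3 is therefore estimated at 35 nM, in the range 12 nM to 100 nM.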

Compound 3, half-maximal inhibitory concentration: 36 nM
For compound 3 the middle estimate is 1.0-fold (0.01 log units) below the measured one, and the stated range covers the measured number.
By their numbers in this assay, from the lowest: compounds 2, 3 and 1 (each within the scatter of the next).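

In this assay, the aromatic carbon para to a large group accepts either octyl or 4-fluorophenoxy: the exchange gives a 1.4-fold higher number from compound 2 to compound 3 (0.16 log units; within the scatter), so a chain and a group carrying an aromatic ring cannot be told apart here. Methoxycarbonyl in place of chloro on an aromatic carbon gives a 1.2-fold lower number from compound 1 to compound 3 (0.07 log units; within the scatter), so these two groups cannot be told apart either. No evidence is available that bears on these results. The compounds shown leave open whether a shorter chain such as butyl at the first position, or a carboxylic acid in place of methoxycarbonyl, would give a number outside the scatter.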